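This account rests on a few compounds, and the source may have more. Where it says the series, first, only, none or still open, it means among the compounds named here.

Measured compounds:
compound 1, `CC(C)C(NC(=O)C(CC(=O)O)NC(=O)CCCOc1ccc(C(=N)N)cc1)C(=O)O`: 1.29
compound 2, `CC(C)CC(NC(=O)C(CC(=O)O)NC(=O)CCCOc1ccc(C(=N)N)cc1)C(=O)O`: 1.47
compound 3, `CC(C)C(NC(=O)C(CC(=O)O)NC(=O)CCCCOc1ccc(C(=N)N)cc1)C(=O)O`: 1.32

In a physicochemical assay for lipophilicity (a higher number here means a more lipophilic compound, a lower number a more polar compound), compound 1 stands lowest of the three numbers, with compound 3 nearest and compound 2 furthest, both within the scatter of compound 1. Compound 4, `CC(C)c1ccc(OCCNC(=O)C(CC(=O)O)NC(=O)CCCOc2ccc(C(=N)N)cc2)cc1`, differs from compound 1 by 2-(4-isopropylphenoxy)ethyl in place of 1-carboxy-2-methylpropyl on an amide-type nitrogen. Within the data shown here, the one measured step on the same part of the molecule, a number 0.18 log units higher from compound 1 to compound 2 (within the scatter), exchanges one small alkyl group for another; compounds 1 and 3 differ only in the length of the linker and their values lie within the scatter. Among the measured compounds shown here, no measured step removes a carboxylic acid or adds an aromatic ring, so the change leading to compound 4 is much larger than anything seen among compounds 1 to 3. An upward step of a number 1.71 log units higher from compound 1 to compound 4 (beyond the scatter) is therefore expected, with broad uncertainty. For compound 4 the estimate is 3, within a range of 2.2 to 3.8.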

Compound 4, partition coefficient: 2.21
For compound 4 the middle estimate is 0.79 log units above the measured one, and the stated range covers the measured number.
By their numbers in this assay, from the lowest: compounds 1, 3 and 2 (each within the scatter of the next); then compound 4.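

Compound 4 carries 2-(4-isopropylphenoxy)ethyl on the amide-type nitrogen. In this assay the steps of a number 0.92 log units higher from compound 1 to compound 4 (beyond the scatter) and a number 0.74 log units higher from compound 2 to compound 4 (beyond the scatter) both lie beyond the scatter. This position therefore allows steps beyond the scatter, which the earlier step at this position did not show. Nothing available here accounts for their size. The change removes a carboxyl group and adds an aromatic ring at once, so the compounds shown do not separate the two contributions. Going by these compounds, how a methyl ester in place of that carboxylic acid, or an unsubstituted phenoxyethyl group, would compare remains open.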